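Swapping a Ring Group and Following Microsomal Clearance

A few compounds are considered here, and "the series" means these few. Any claim that something is new, unique, unknown or untested is made for them only; others in the source may bear on it.

Measured in an ADME assay on microsomes from liver (Homo sapiens) for metabolic stability; a lower number here means slower removal, a higher number faster removal of the compound:
Compound 1 `CCn1cnc2c(-c3ccc(F)c(Oc4cnc(C#N)nc4)c3)cnnc21`: 49 mL.min-1.g-1
Compound 2 `CCn1cnc2c(-c3ccc(F)c(Oc4ccc(C#N)cn4)c3)cnnc21`: 65 mL.min-1.g-1

Compound 2, at 65 mL.min-1.g-1, stands level with compound 1, at 49 mL.min-1.g-1, once the usual scatter of this assay is taken into account. The structure still to be measured is compound 3 `CCn1cnc2c(-c3ccc(F)c(-c4ccnc(C)c4)c3)cnnc21`. Its change from compound 2 is larger than a swap of one ring on the oxygen: 2-methylpyridin-4-yl in place of (5-cyanopyridin-2-yl)oxy on an aromatic carbon. In words, 2-methylpyridin-4-yl takes the place of (5-cyanopyridin-2-yl)oxy on an aromatic carbon, ortho to a fluoro group, so the oxygen link and the nitrile both leave.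

Among the compounds with values here, only one measured step bears on this, and it is a 1.3-fold higher number from compound 1 to compound 2 (0.12 log units; within the scatter). That step put 5-cyanopyridin-2-yl in place of 2-cyanopyrimidin-5-yl and kept the oxygen, so it is a weak guide here. Within the data shown here, no measured compound lacks the oxygen link, so the data point in no firm direction, and the range has to stay wide. The expected change is a 1.4-fold lower number from compound 2 to compound 3 (0.16 log units; within the scatter), which means no step beyond the scatter. The estimate for compound 3 is 45 mL.min-1.g-1, with an expected range of 18 mL.min-1.g-1 to 100 mL.min-1.g-1.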

Compound 3, intrinsic clearance in microsomes: 157 mL.min-1.g-1
The estimate for compound 3 lay 3.5-fold (0.54 log units) below the measured number; measured number above the stated range.
By their numbers in this assay, from the lowest: compounds 1 and 2 (each within the scatter of the next); then compound 3.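

In this assay, the place on an aromatic carbon ortho to a fluoro group now shows a change beyond the scatter: putting 2-methylpyridin-4-yl in place of (5-cyanopyridin-2-yl)oxy gives a 2.4-fold higher number from compound 2 to compound 3 (0.38 log units; beyond the scatter). The comparison with the other compound that has a ring on the oxygen points the same way, with a 3.2-fold higher number from compound 1 to compound 3 (0.51 log units; beyond the scatter), so this position does respond to the group it carries, which the swap between two nitrile-bearing rings on the oxygen could not show. Nothing available explains why the number rose at this position.

This single change removes the oxygen link and the nitrile and brings in a methyl on a different ring, so the compounds shown cannot say which of these parts accounts for the rise. As far as these compounds go, a plain pyridin-4-yl without the methyl, or a 5-cyanopyridin-2-yl joined straight to the aromatic carbon with no oxygen, would pull those parts apart, and other groups here, such as an amine or a methoxy on the ring, remain open as well.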